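The source may hold more compounds than are shown below. What is called first, only, known or untested is meant among the compounds shown, and "the series" means these compounds.

Of the compounds shown here, three of one series have been tested in an assay on isolated protein for displacement of a labelled ligand from metabotropic glutamate receptor 5 (Homo sapiens), with a stated time of 60 min, tested at 1 uM; on this read-out higher numbers stand for more inhibition at the one concentration tested (going by the name of the read-out) and lower numbers for less inhibition. Compound 1 `CC1CCN(c2c(S(=O)(=O)c3ccccc3)cnc3c(F)cccc23)CC1` gives 13%. Compound 2 `CC1CCN(c2c(S(=O)(=O)c3ccc(Cl)cc3)cnc3c(F)cccc23)CC1` gives 85%, and compound 3 `CC1CCN(c2c(S(=O)(=O)c3cc(Cl)cc(Cl)c3)cnc3c(F)cccc23)CC1` gives 82%. On these numbers compound 3 stands second highest of three: its nearest neighbour is compound 2, and the step of a number 3 percentage points lower from compound 2 to compound 3 (within the scatter) lies within the scatter, while compound 1 lies far below it, as the step of a number 69 percentage points higher from compound 1 to compound 3 (beyond the scatter) shows.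

Compound 4 `CC1CCN(c2c(S(=O)(=O)c3ccc(F)c(F)c3)cnc3c(F)cccc23)CC1` differs from compound 3 in one place: 3,4-difluorophenyl in place of 3,5-dichlorophenyl on a sulfonyl sulfur. Among the measured compounds shown here, two measured steps bear on this change. The step of a number 72 percentage points higher from compound 1 to compound 2 (beyond the scatter) and the step of a number 69 percentage points higher from compound 1 to compound 3 (beyond the scatter) show that putting chlorine onto the phenyl ring on the sulfonyl sulfur raised the read-out sharply, whereas the step of a number 3 percentage points lower from compound 2 to compound 3 (within the scatter) shows that moving from one chlorine pattern to another changed little. For the measured compounds named here, no measured step exchanges chlorine for fluorine, so the size of the coming step is uncertain. It is estimated that compound 4 will sit somewhat below compound 3, a step of a number 22 percentage points lower from compound 3 to compound 4 (beyond the scatter), and compound 4 is expected to give 60% in this assay, with a range from 20% to 90%.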

Compound 4, a percentage reported as inhibition, at one concentration (the size of the read-out at that concentration, not a potency): 93%
Compound 4: the middle estimate sits 33 percentage points below what was measured; the whole stated range lies below it.
By their numbers in this assay, from the lowest: compound 1; then compounds 3, 2 and 4 (each within the scatter of the next, the first and the last beyond it).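

In this assay chlorine is not required on the phenyl ring at this sulfonyl sulfur: 3,4-difluorophenyl in place of phenyl gives a number 80 percentage points higher from compound 1 to compound 4 (beyond the scatter) with fluorine alone on that ring. Against the chlorinated rings the outcome depends on the partner, with a number 11 percentage points higher from compound 3 to compound 4 (beyond the scatter) as a modest rise over the 3,5-dichlorophenyl group, while a number 8 percentage points higher from compound 2 to compound 4 (within the scatter) leaves 3,4-difluorophenyl and 4-chlorophenyl unseparated.

The compounds shown leave open how a 4-fluorophenyl, 4-methoxyphenyl or pyridyl group on the sulfonyl sulfur would read, and how the halogenated compounds compare in potency, since a read-out at one concentration is not a potency. Nothing measured here gives a reason for these steps.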